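The source may report more compounds than this note shows. Statements on the series, on what has been measured and on what is new or still open speak of the compounds shown alone.

Measured so far:
- compound 1, `CC(C)=CC(=O)Nc1c(C(O)(C(F)(F)F)C(F)(F)F)ccc2ccccc12`, in an assay on LtK cells with ATP-sensitive inward rectifier potassium channel 11 (Homo sapiens) as the target (a higher number here means that more compound is needed for the effect, a lower number that less compound is needed), compound 1 gives 46 nM
- compound 2, `O=C(CCc1ccccc1)Nc1c(C(O)(C(F)(F)F)C(F)(F)F)ccc2ccccc12`, in this assay compound 2 gives 1750 nM

Compound 2 stands at the highest of the two numbers, so it needs the most compound of the pair. For the measured compounds named here, the one measured step, a 38-fold higher number from compound 1 to compound 2 (1.58 log units; beyond the scatter), shows how strongly the group attached to the carbonyl carbon governs the outcome: that step is large. Compound 3, `O=C(Nc1c(C(O)(C(F)(F)F)C(F)(F)F)ccc2ccccc12)c1cccc(Br)c1`, has not been measured. It changes the same position again: 3-bromophenyl in place of phenethyl on a carbonyl carbon. The measured step bears on it only in that it marks this position as sensitive; it does not say which way a ring placed directly on the carbonyl will turn the number. A step of moderate size in either direction is plausible, with wide uncertainty. The estimate for compound 3 in this assay is 600 nM, expected to lie between 100 nM and 4000 nM. This estimated step, a 2.9-fold lower number from compound 2 to compound 3 (0.46 log units; beyond the scatter), is expected to be smaller than the one already measured.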

Compound 3, half-maximal effective concentration: 80 nM
For compound 3 the middle estimate is 7.5-fold (0.88 log units) above the measured one; measured number below the stated range.
By their numbers in this assay, from the lowest: compounds 1 and 3 (each within the scatter of the next); then compound 2.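

Replacing phenethyl with 3-bromophenyl on the carbonyl carbon gives a 22-fold lower number from compound 2 to compound 3 (1.34 log units; beyond the scatter) in this assay. Both groups carry one six-membered aromatic ring of carbon only, so the presence of such a ring does not by itself go with the high number of compound 2. The other new comparison, a 1.7-fold higher number from compound 1 to compound 3 (0.24 log units; within the scatter), shows that 3-bromophenyl and 2-methylprop-1-en-1-yl cannot be told apart here despite their different structures, and no measurement is available to explain these results.

From the compounds shown here alone, what the bromine contributes remains open, and a plain phenyl group or a chlorine in its place would test this. It is also unknown how benzyl, with a shorter chain than phenethyl, or an amine on the carbonyl carbon would behave.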